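The compounds below may be only part of what the source reports. "The series", "measured", "known", "first", "only" and "open" are said of these compounds alone.

Measured in a functional assay on the whole organism with Mus musculus as the target; a lower number here means that less compound is needed, a higher number that more compound is needed for the effect:
- compound 1 `CCNC(=O)/C=C/c1cccc(C(F)(F)F)c1`: 90 mg/kg
- compound 2 `CN(C)C(=O)CCC(=O)c1cccc(C(F)(F)F)c1`: > 50 mg/kg

Compound 2 stands at > 50 mg/kg, and this is a limit of the assay, not a number. Among the compounds with values here, the only actual number is therefore that of compound 1, at 90 mg/kg. Within the data shown here, no step between compounds differing in one place has been measured, so the size of any change at this position is unknown.

Compound 3 `CCC(C)NC(=O)CCC(=O)c1cccc(C(F)(F)F)c1` keeps the core of compound 2 and has (sec-butyl)amino in place of dimethylamino on a carbonyl carbon.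

With compound 1 at 90 mg/kg as the sole anchor, no step beyond the usual scatter is expected in this assay. The expected step, a step that the limit leaves unreadable from compound 2 to compound 3, is a weak estimate. A further limit rather than a number would not be surprising.

For compound 3 the estimated value is 70 mg/kg, with an expected range of 30 mg/kg to 160 mg/kg.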

Compound 3, dose for half-maximal effect: > 200 mg/kg
Compound 3 gave a limit, no number (the forecaster's own chance of this, stated with the estimate: 35%); middle value at least 2.8-fold (0.45 log units) away from the limit.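

Compound 2 and compound 3 both stand as limits in this assay, not as numbers, so no step can be read between them. The compounds shown leave open how large the effect of (sec-butyl)amino in place of dimethylamino on a carbonyl carbon is, and in which direction it runs.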